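This account rests on a few compounds, and the source may have more. Where it says the series, first, only, none or still open, it means among the compounds named here.

Measured so far in a physicochemical assay for lipophilicity; a higher number here means a more lipophilic compound, a lower number a more polar compound:
- compound 1, `CCCCCc1nc2ccccc2[nH]1`: 3.43
- compound 2, `CCCCCCCCc1nc2ccccc2[nH]1`: 4.93
- compound 3, `CC(=O)Nc1ccc2[nH]c(C)nc2c1`: 0.61

Compound 1 and compound 2 share a core and differ by propyl in place of hydrogen on a saturated chain carbon, five bonds along the chain from an aromatic carbon. This gave a number 1.50 log units higher from compound 1 to compound 2 (beyond the scatter). Compound 3 stands lowest of the three; the difference between its core and the core of compound 1 is not broken down here.

Compound 4, `CCCCC(=O)Nc1ccc2[nH]c(C)nc2c1`, has not yet been measured in this assay. It differs from compound 3 by propyl in place of hydrogen on a saturated chain carbon bound to a carbonyl carbon. Going by the values given here, this is the same kind of change as the one from compound 1 to compound 2, but not the same: in the earlier pair the new group sits on a saturated chain carbon five bonds along the chain from an aromatic carbon, whereas here it sits on a saturated chain carbon bound to a carbonyl carbon. Among the compounds with values here, the earlier step is the only guide available, so beside it the expected step here is a number 1.39 log units higher from compound 3 to compound 4 (beyond the scatter), resting on the size of the measured step from compound 1 to compound 2. Compound 4 is therefore estimated at 2, expected between 1.6 and 2.5.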

Compound 4, partition coefficient: 2.11
Estimate against measurement, compound 4: 0.11 log units below; the measured number falls inside the stated range.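

In this assay, the same swap of hydrogen for propyl gave a number 1.50 log units higher from compound 3 to compound 4 (beyond the scatter), matching in size a number 1.50 log units higher from compound 1 to compound 2 (beyond the scatter), even though the two pairs have different cores and the new group sits in a different place. Within these two pairs, then, the size of the step carried over from one core to the other, and the step measured on the core of compound 1 served as a usable guide for the core of compound 3. Two pairs do not make a general rule, however: they do not show that the step would keep this size on a third core or in any other kind of measurement, and nothing available explains why the two steps agree.

The compounds shown leave open whether a longer chain in place of propyl would continue to raise the number in the same way on both cores. They also leave open what an amine or a carboxylic acid would do in place of propyl, and whether such a change would carry from one core to the other as closely as this one did.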